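Swapping a chloro for a methyl on the sulfonyl aryl ring

The compounds below may be only part of what the source reports. "The series", "measured", "known", "first", "only" and "open" are said of these compounds alone.

Measured so far:
- Compound 1 `O=C(NCc1ccc(CNS(=O)(=O)c2ccc3c(c2)CCO3)cc1)c1ccc(F)cc1` — 10 nM
- Compound 2 `O=C(NCc1ccc(CNS(=O)(=O)c2cccnc2)cc1)c1ccc(F)cc1` — 1000 nM
- Compound 3 `O=C(NCc1ccc(CNS(=O)(=O)c2ccc(Cl)cc2)cc1)c1ccc(F)cc1` — 100 nM

These values come from an assay on MDA-MB-231 cells for binding affinity to C-X-C chemokine receptor type 4 (Homo sapiens), read by fluorescence and microscopy, with stated times of 10 min and 30 min; a lower number here means that less compound is needed, a higher number that more compound is needed for the effect. Among the three, compound 3 stands in the middle: compound 1 sits a 10-fold higher number from compound 1 to compound 3 (1.00 log units; beyond the scatter) away on the stronger side, while compound 2 sits on the weaker side with a 10-fold lower number from compound 2 to compound 3 (1.00 log units; beyond the scatter).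

Compound 4 `Cc1cccc(S(=O)(=O)NCc2ccc(CNC(=O)c3ccc(F)cc3)cc2)c1` is not yet measured. It differs from compound 3 by 3-methylphenyl in place of 4-chlorophenyl on a sulfonyl sulfur. For the measured compounds named here, the steps that bear on this are a 10-fold lower number from compound 2 to compound 3 (1.00 log units; beyond the scatter) and a 10-fold higher number from compound 1 to compound 3 (1.00 log units; beyond the scatter), both of which also replace the ring on the sulfonyl sulfur, but neither involves a methyl-bearing ring, so they only show that this position is sensitive. A small shift is therefore expected, a 1.5-fold higher number from compound 3 to compound 4 (0.18 log units; within the scatter), giving an estimated value for compound 4 of 150 nM with a range of 40 nM to 600 nM.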

Compound 4, effective concentration (reported as EC, without a stated level of effect): 1 nM
The estimate for compound 4 lay 150-fold (2.18 log units) above the measured number; the measured number lies below the stated range.
By their numbers in this assay, from the lowest: compound 4; then compound 1; then compound 3; then compound 2.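

With the count of heavy atoms unchanged, the step to 3-methylphenyl from 4-chlorophenyl gives a 100-fold lower number from compound 3 to compound 4 (2.00 log units; beyond the scatter) on the sulfonyl sulfur, so this position responds strongly even to a swap of equal count. The one-ring 3-methylphenyl also outdoes the two-ring group, a 10-fold lower number from compound 1 to compound 4 (1.00 log units; beyond the scatter) here, and pyridin-3-yl, a 1000-fold lower number from compound 2 to compound 4 (3.00 log units; beyond the scatter) in that case, so a second ring is not required for the lowest number. Nothing measured here explains this change.

The compounds shown leave open whether the methyl itself or its place on the ring matters; 3-chlorophenyl and 4-methylphenyl would separate the two. On these data alone, how an amine or a carboxylic acid on this ring would read also remains open.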